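From compound 2 to compound 3: a swap to iodo

The source may hold more compounds than are shown below. What is called first, only, known or untested is meant among the compounds shown, and "the series" means these compounds.

Compound 1 (`COC(=O)N[C@H](C(=O)NN(CCC[C@@](O)(Cc1ccccc1)C(=O)N[C@H]1c2ccccc2C[C@H]1O)Cc1ccc(Br)cc1)C(C)(C)C`) and compound 2 (`COC(=O)N[C@H](C(=O)NN(CCC[C@@](O)(Cc1ccccc1)C(=O)N[C@H]1c2ccccc2C[C@H]1O)Cc1ccc(OCc2cnc(Cl)s2)cc1)C(C)(C)C`) share one core. In an ADME assay on MT4 cells (Homo sapiens) for cytotoxicity (on this read-out lower numbers stand for higher toxicity in this test and higher numbers for lower toxicity in this test), compound 1 gives > 10000 nM, which is a limit of the assay and not a number. In this assay compound 2 gives > 10000 nM, again a limit and not a number. Compound 2 therefore has no exact value and stands at the limit of > 10000 nM in this assay, at which 2 of the 2 values shown sit.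

Compound 3 (`COC(=O)N[C@H](C(=O)NN(CCC[C@@](O)(Cc1ccccc1)C(=O)N[C@H]1c2ccccc2C[C@H]1O)Cc1ccc(I)cc1)C(C)(C)C`) has not yet been measured. The change that leads to it from compound 2 is iodo in place of (2-chloro-1,3-thiazol-5-yl)methoxy on an aromatic carbon. In words, this is iodo in place of (2-chloro-1,3-thiazol-5-yl)methoxy on an aromatic carbon.

Going by the values given here, the one measured step that bears on this change is a step that the two limits leave unreadable from compound 1 to compound 2, where (2-chloro-1,3-thiazol-5-yl)methoxy took the place of bromo on an aromatic carbon. Both ends of that step sit at the limit, so it offers no size to carry over. No step beyond the scatter is expected in this assay, and no direction can be given with confidence. The expected change is a step that the limit leaves unreadable from compound 2 to compound 3. Compound 3 is estimated at 15000 nM, with an expected range from 7000 nM to 40000 nM.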

Compound 3, half-maximal cytotoxic concentration: > 10000 nM
Compound 3: only a limit was reported (the forecaster's own chance of this, stated with the estimate: 85%); the middle value does not contradict the limit.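

Compound 3 gives only a limit in this assay and not a number, so no step can be read among compound 1, compound 2 and compound 3: the limit of > 10000 nM in this assay, at which 3 of the 3 values shown sit.

The compounds shown leave open whether bromo, iodo and (2-chloro-1,3-thiazol-5-yl)methoxy differ at all in this assay, and at what concentration any of these compounds would harm the cells.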